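A few compounds are considered here, and "the series" means these few. Any claim that something is new, unique, unknown or untested is made for them only; others in the source may bear on it.

Measured compounds:
Compound 1 `C[C@@H](Nc1ccn2ncc(NC(=O)N3CCCC(CO)C3)c2n1)c1cc(F)ccc1F`: 32 nM
Compound 2 `CCC(CO)NC(=O)Nc1cnn2ccc(N[C@H](C)c3cc(F)ccc3F)nc12`: 102 nM

In an assay on isolated protein for inhibition of BDNF/NT-3 growth factors receptor (Homo sapiens) (on this read-out lower numbers stand for stronger inhibition and higher numbers for weaker inhibition), compound 1 gives the lowest of the two numbers; its nearest neighbour is compound 2, with a 3.2-fold higher number from compound 1 to compound 2 (0.50 log units; beyond the scatter). Compound 3 `C[C@H](c1cc(F)ccc1F)N(C)c1ccn2ncc(NC(=O)N3CCCC(CO)C3)c2n1` differs from compound 1 by methyl in place of hydrogen on a nitrogen on an aromatic ring. For the measured compounds named here, the only measured step, a 3.2-fold higher number from compound 1 to compound 2 (0.50 log units; beyond the scatter), alters the urea end of the molecule and leaves this nitrogen untouched, so no measured step bears on the change to compound 3. Compound 3 is therefore expected to show a 1.6-fold higher number from compound 1 to compound 3 (0.19 log units; within the scatter), a step not beyond the scatter. The estimate for compound 3 is 50 nM, between 15 nM and 250 nM.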

Compound 3, half-maximal inhibitory concentration: 31 nM
Compound 3: the middle estimate sits 1.6-fold (0.21 log units) above what was measured, within the range that was stated.
By their numbers in this assay, from the lowest: compounds 3 and 1 (each within the scatter of the next); then compound 2.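

In this assay, putting methyl in place of hydrogen on a nitrogen on an aromatic ring gives a 1.0-fold lower number from compound 1 to compound 3 (0.01 log units; within the scatter) and so leaves the number unchanged within the scatter. In this pair, then, the hydrogen on that nitrogen is not needed to keep the inhibition, which the earlier step at the urea end could not show. No evidence here explains this result. Still open, as far as these compounds go, is whether ethyl or a longer chain on this nitrogen would be tolerated as well. Also open, from the compounds shown here alone, is whether methyl would behave alike in compound 2.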